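A Larger Anilino Group Tried on a Shared Core

The compounds below may be only part of what the source reports. "The series", "measured", "known", "first", "only" and "open" are said of these compounds alone.

Compound 1 `CCS(=O)(=O)Nc1cc(-c2ccc3ncnc(Nc4cccc(F)c4)c3c2)cnc1OC`: 8020 nM
Compound 2 `CCS(=O)(=O)Nc1cc(-c2ccc3ncnc(Nc4ccc(F)c(C(=O)OC)c4)c3c2)cnc1OC`: 1150 nM

In a functional assay on MCF7 cells (Homo sapiens) for cytotoxicity, read by sulforhodamine B assay, with a stated time of 72 h (a lower number here means a stronger inhibitor, a higher number a weaker inhibitor), compound 1 gives 8020 nM, the higher of the two numbers measured, so it is the weaker inhibitor of the pair. Compound 3 `CCS(=O)(=O)Nc1cc(-c2ccc3ncnc(Nc4ccc(Cl)c(C(=O)OC)c4)c3c2)cnc1OC` is not yet measured and differs from compound 1 in one place: 4-chloro-3-(methoxycarbonyl)phenyl in place of 3-fluorophenyl on a nitrogen on an aromatic ring. Going by the values given here, the only measured step that bears on this change is a 7.0-fold lower number from compound 1 to compound 2 (0.84 log units; beyond the scatter), where the same methoxycarbonyl group entered alongside a fluorine rather than a chlorine. A step of similar size and direction is therefore expected for compound 3, namely an 8.0-fold lower number from compound 1 to compound 3 (0.90 log units; beyond the scatter). Compound 3 is estimated at 1000 nM, in a range from 350 nM to 3000 nM.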

Compound 3, half-maximal inhibitory concentration: 1430 nM
Estimate against measurement, compound 3: 1.4-fold (0.16 log units) below; low and high end bracket the measured number.
By their numbers in this assay, from the lowest: compounds 2 and 3 (each within the scatter of the next); then compound 1.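

With 4-chloro-3-(methoxycarbonyl)phenyl in place of 3-fluorophenyl, this assay shows a 5.6-fold lower number from compound 1 to compound 3 (0.75 log units; beyond the scatter) and so the drop seen with the fluoro partner also appears with a chloro partner. Chloro in place of fluoro on an aromatic carbon gives a 1.2-fold higher number from compound 2 to compound 3 (0.09 log units; within the scatter) and so this swap separates the two compounds by no more than ordinary scatter. Nothing available here explains either step. Still open, on these data alone, is what the methoxycarbonyl group does with no halogen on its ring, and how a carboxylic acid or an amide would compare in its place.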